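The compounds below may be only part of what the source reports. "The series", "measured", "known", "first", "only" and "open" are said of these compounds alone.

Measured so far in a functional assay on MCF7 cells (Homo sapiens) for inhibition, with a stated time of 96 h; on this read-out lower numbers stand for stronger inhibition and higher numbers for weaker inhibition:
- compound 1 `COc1cc(C(=O)c2cn(-c3ccc(F)cc3)cc2-c2ccsc2)cc(OC)c1OC`: 15 nM
- compound 2 `COc1cc(C(=O)c2cn(-c3ccc(F)cc3)cc2-c2ccoc2)cc(OC)c1OC`: 15 nM

In this assay, among the measured compounds shown here, compound 2, at 15 nM, stands level with compound 1, its nearest neighbour on the numbers so far. Compound 3 `COc1cc(C(=O)c2cn(-c3ccc(F)cc3)cc2-c2ncco2)cc(OC)c1OC` has 1,3-oxazol-2-yl in place of furan-3-yl on an aromatic carbon, on the shared core of compound 2: 1,3-oxazol-2-yl in place of furan-3-yl on an aromatic carbon.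

For the measured compounds named here, only one measured step bears on this exchange: no change at the digits printed from compound 1 to compound 2 (within the scatter), with furan-3-yl in place of thiophen-3-yl. It shows one ring exchange passing without a visible shift. Going by the values given here, in that step, however, each ring has a single hetero atom, and no measured compound carries a ring with two. The series therefore offers no direct guide to the new exchange, and the size of the shift is a matter of judgement.

Among the compounds with values here, with no change at the digits printed from compound 1 to compound 2 (within the scatter) as the only precedent, a moderate loss is expected rather than a large one, though no change remains possible. The expected step is a 3.3-fold higher number from compound 2 to compound 3 (0.52 log units; beyond the scatter). The estimate for compound 3 is 50 nM, with an expected range of 15 nM to 250 nM.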

Compound 3, half-maximal inhibitory concentration: 93 nM
Compound 3: the middle estimate sits 1.9-fold (0.27 log units) below what was measured; the range from low to high includes it.
By their numbers in this assay, from the lowest: compounds 1 and 2 (each within the scatter of the next); then compound 3.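

In this assay, this position, on an aromatic carbon next to the ring atom that bears a large group, turns out not to accept every five-membered aromatic ring equally: 1,3-oxazol-2-yl gives a 6.2-fold higher number from compound 2 to compound 3 (0.79 log units; beyond the scatter) and a 6.2-fold higher number from compound 1 to compound 3 (0.79 log units; beyond the scatter), whereas the earlier exchange of thiophen-3-yl for furan-3-yl gave no change at the digits printed from compound 1 to compound 2 (within the scatter). Compound 3 is the only compound shown with a ring of 2 hetero atoms, and in this exchange the counts of hetero atoms and hydrogen-bond acceptors both rise from 1 to 2, so the step cannot assign the loss to either count alone. No supporting measurement accompanies this result, so the data give no account of the shift.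

The compounds shown leave open whether the loss belongs to the ring nitrogen itself or to the way the ring is attached, a question that 1,3-oxazol-5-yl or 1,3-thiazol-2-yl at the same position would bear on. They also leave open whether phenyl or pyridin-3-yl, both six-membered rings, would stay level with compound 2 or follow compound 3.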